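This account rests on a few compounds, and the source may have more. Where it says the series, first, only, none or still open, it means among the compounds named here.

Compound 2 `CCc1nc(NC(C)C)c2cnn(-c3ccccc3)c2n1` sits at the top of the two numbers in hand for a functional assay on G-361 cells (Homo sapiens) for cytotoxicity, read by sulforhodamine B assay; on this read-out lower numbers stand for stronger inhibition of growth and higher numbers for weaker inhibition of growth: compound 2 gives 38000 nM, whereas compound 1 `CCCNc1nc(CC)nc2c1cnn2-c1ccccc1` gives 2200 nM. Among the measured compounds shown here, the only step between these two is a 17-fold higher number from compound 1 to compound 2 (1.24 log units; beyond the scatter), and it runs well beyond the scatter. Compound 3 `CCCCNc1nc(CC)nc2c1cnn2-c1ccccc1` is the next member and has not yet been run in this assay. Against compound 2 the change is butyl in place of isopropyl on a nitrogen on an aromatic ring, that is, isopropylamino to butylamino. For the measured compounds named here, the single step that bears on this is a 17-fold higher number from compound 1 to compound 2 (1.24 log units; beyond the scatter), which went from a propyl chain to a branched isopropyl; the move to butyl restores an unbranched chain, one carbon longer than propyl. On that basis compound 3 is expected to move back towards compound 1, with a step of about a 13-fold lower number from compound 2 to compound 3 (1.10 log units; beyond the scatter) expected. The estimate for compound 3 is 3000 nM, within a range of 800 nM to 12000 nM.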

Compound 3, concentration for 50% growth inhibition: 2020 nM
For compound 3 the middle estimate is 1.5-fold (0.17 log units) above the measured one; low and high end bracket the measured number.
By their numbers in this assay, from the lowest: compounds 3 and 1 (each within the scatter of the next); then compound 2.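

In this assay, the unbranched butyl removes the loss seen with isopropyl at this nitrogen (a 19-fold lower number from compound 2 to compound 3 (1.27 log units; beyond the scatter)), so the earlier large step is not a one-off feature of propyl. Extending the straight chain by one carbon makes no difference that can be read (a 1.1-fold lower number from compound 1 to compound 3 (0.04 log units; within the scatter)), which leaves isopropyl as the only one of these three groups with a number set apart from the others. Nothing available here accounts for the gap between the branched chain and the two straight chains.

Still open, going by these compounds, is whether a longer chain such as pentyl stays level with propyl and butyl, or whether the numbers begin to move again. Also open, on these data alone, is whether branching further out, as in isobutyl, or a ring such as cyclopentyl on the same nitrogen, behaves like isopropyl.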